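The compounds below may be only part of what the source reports. "The series", "measured", "known", "first", "only" and "open" are said of these compounds alone.

Working notes on the series. In an assay (Rattus norvegicus) for inhibition of Fatty-acid amide hydrolase 1 (Homo sapiens) (on this read-out higher numbers stand for weaker inhibition and lower numbers for stronger inhibition), compound 1 `NS(=O)(=O)c1ccccc1-c1cnc(C(=O)CCCCCCc2ccccc2)o1` gives 1500 nM. Compound 2 `O=C(CCCCCCc1ccccc1)c1ncc(-c2ccc([N+](=O)[O-])cc2)o1` gives 50 nM in this assay, the second highest of the three numbers; its nearest neighbour is compound 3 `NS(=O)(=O)c1ccc(-c2cnc(C(=O)CCCCCCc3ccccc3)o2)cc1`, which gives 10 nM, and its furthest is compound 1. Going by the values given here, the one step that can be traced, a 5.0-fold lower number from compound 2 to compound 3 (0.70 log units; beyond the scatter), comes from the exchange at the same aromatic carbon that is varied next, and is modest. Compound 4 `Cc1ccnc(-c2cnc(C(=O)CCCCCCc3ccccc3)o2)c1` has not yet been measured in this assay. Its difference from compound 2 is 4-methylpyridin-2-yl in place of 4-nitrophenyl on an aromatic carbon. Among the compounds with values here, no measured step exchanges a nitro-bearing ring for a pyridine ring, so the step from compound 2 to compound 3 bears only loosely, showing that a change at this carbon can move the number by a modest amount in either direction. A step near the scatter, or a little upward, is expected: the estimate for compound 4 is 100 nM, between 20 nM and 500 nM, meaning an expected step of a 2.0-fold higher number from compound 2 to compound 4 (0.30 log units; within the scatter).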

Compound 4, inhibition constant: 0.6 nM
For compound 4 the middle estimate is 170-fold (2.22 log units) above the measured one, and the stated range ends above it.
By their numbers in this assay, from the lowest: compound 4; then compound 3; then compound 2; then compound 1.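

In this assay, the exchange on this aromatic carbon next to the ring oxygen gives an 83-fold lower number from compound 2 to compound 4 (1.92 log units; beyond the scatter), a large step, whereas the earlier exchange at the same carbon, a 5.0-fold lower number from compound 2 to compound 3 (0.70 log units; beyond the scatter), was only modest. Going by these compounds alone, the group here can therefore move the number much further than the earlier compounds showed, and a six-membered aromatic ring with 1 hetero atom and a methyl group is compatible with a low number without a nitro or sulfamoyl group. Nothing available accounts for the size of this step.

On these data alone, the ring nitrogen, the methyl group and the loss of the nitro group all change together, so the share of each in the step remains open. An unsubstituted pyridin-2-yl or a 4-methylphenyl on this carbon would help to separate them.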